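A few compounds are considered here, and "the series" means these few. Any claim that something is new, unique, unknown or untested is made for them only; others in the source may bear on it.

Measured in an assay on Sf9 cells for inhibition of Leucine-rich repeat serine/threonine-protein kinase 2 (Homo sapiens), read by TR-FRET, with stated times of 30 min and 2 h; a higher number here means a weaker inhibitor, a lower number a stronger inhibitor:
compound 1 `CN1CC2(C1)CN(c1ccc(OCc3ccccc3)c(C(=O)Nc3ccnnc3)c1)C2`: 25.1 nM
compound 2 `CN1CCC(c2ccc(OCc3ccccc3)c(C(=O)Nc3ccnnc3)c2)CC1`: 20 nM
compound 3 `O=C(Nc1ccnnc1)c1cc(N2CCC(O)CC2)ccc1OCc1ccccc1`: 39.8 nM

Compound 1 stands second highest of the three numbers, and its steps to both neighbours lie within the scatter: a 1.3-fold lower number from compound 1 to compound 2 (0.10 log units; within the scatter), and a 1.6-fold higher number from compound 1 to compound 3 (0.20 log units; within the scatter). The remaining pair also stays within the scatter: a 2.0-fold higher number from compound 2 to compound 3 (0.30 log units; within the scatter). Compound 4 `CN1CC2(CCN(c3ccc(OCc4ccccc4)c(C(=O)Nc4ccnnc4)c3)CC2)C1` differs from compound 1 on the same aromatic carbon: a group of 10 heavy atoms (8 carbon, 2 nitrogen; one four-membered non-aromatic ring with 1 hetero atom, one six-membered non-aromatic ring with 1 hetero atom) in place of a group of 8 heavy atoms (6 carbon, 2 nitrogen; 2 four-membered non-aromatic rings with 1 hetero atom each), on an aromatic carbon. All three measured steps concern exchanges of the group on that aromatic carbon, and none of them moved the number beyond the scatter, so for this assay no step beyond the scatter is expected here either; the expected step is a 1.1-fold lower number from compound 1 to compound 4 (0.06 log units; within the scatter). Compound 4 is therefore estimated at 22 nM in this assay, with a range of 10 nM to 50 nM.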

Compound 4, half-maximal inhibitory concentration: 63.1 nM
Beside the measured number, compound 4's estimate is 2.9-fold (0.46 log units) below it; the whole stated range lies below it.
By their numbers in this assay, from the lowest: compounds 2, 1, 3 and 4 (each within the scatter of the next, the first and the last beyond it).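

At this position, para to the benzyloxy group, the group exchange now moves the number in this assay beyond the scatter (a 2.5-fold higher number from compound 1 to compound 4 (0.40 log units; beyond the scatter)) and (a 3.2-fold higher number from compound 2 to compound 4 (0.50 log units; beyond the scatter)), whereas (a 1.6-fold higher number from compound 3 to compound 4 (0.20 log units; within the scatter)) stays within it. The position therefore does not accept every amine-bearing ring equally, even though the groups in compound 1 and compound 4 have the same counts of hydrogen-bond donors and acceptors. Nothing available explains this step.

Open, from the compounds shown here alone, is how an open-chain dimethylamino group or a morpholin-4-yl group would compare on this aromatic carbon.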